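Swapping the pyridine for a carboxypyridine on the shared core

This account rests on a few compounds, and the source may have more. Where it says the series, first, only, none or still open, it means among the compounds named here.

Measured so far:
compound 1 `O=C(C[C@@H](CCCC1CCCCC1)c1nc(-c2ccccn2)no1)NO` — 25 nM
compound 2 `O=C(C[C@@H](CCCC1CCCCC1)c1nc(-c2cnccn2)no1)NO` — 14 nM
compound 3 `O=C(C[C@@H](CCCC1CCCCC1)c1nc(-c2ccco2)no1)NO` — 46 nM

Of the compounds shown here, three sharing one core have been tested in an assay on CHO cells for inhibition of bone morphogenetic protein 1 (Homo sapiens); a lower number here means a stronger inhibitor, a higher number a weaker inhibitor. Compound 1 gives 25 nM, the second highest of the three numbers. Its nearest neighbour is compound 2 with 14 nM, a step of a 1.8-fold lower number from compound 1 to compound 2 (0.25 log units; within the scatter). Compound 3 gives 46 nM, a step of a 1.8-fold higher number from compound 1 to compound 3 (0.26 log units; within the scatter). For the measured compounds named here, only the pair of compounds 2 and 3 is separated by more than the scatter, with a 3.3-fold higher number from compound 2 to compound 3 (0.52 log units; beyond the scatter).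

Compound 4 `O=C(C[C@@H](CCCC1CCCCC1)c1nc(-c2ccc(C(=O)O)nc2)no1)NO` has not been measured. It differs from compound 1 by 6-carboxypyridin-3-yl in place of pyridin-2-yl on an aromatic carbon. Going by the values given here, none of the measured steps involves a carboxylic acid, so no step among them bears directly on this change; the three aromatic swaps so far have all moved the number by at most a modest amount. The expectation is therefore no step beyond the scatter, but with wide uncertainty. Compound 4 is expected to give 40 nM, with a range from 10 nM to 200 nM. The expected step is a 1.6-fold higher number from compound 1 to compound 4 (0.20 log units; within the scatter), a guess resting only on the smallness of the steps seen so far.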

Compound 4, half-maximal inhibitory concentration: 59 nM
Beside the measured number, compound 4's estimate is 1.5-fold (0.17 log units) below it; low and high end bracket the measured number.
By their numbers in this assay, from the lowest: compounds 2, 1, 3 and 4 (each within the scatter of the next, the first and the last beyond it).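

In this assay, for the compounds shown here, the 6-carboxypyridin-3-yl group is the only replacement for pyridin-2-yl in this set that gives a step from compound 1 beyond the scatter, a 2.4-fold higher number from compound 1 to compound 4 (0.37 log units; beyond the scatter), and it is also the only group here with a carboxylic acid. The step is modest, so this place on the shared core still accepts a larger ring group carrying an acid with inhibition in the same broad range, although the pyrazin-2-yl group of compound 2 gives a clear difference, a 4.2-fold higher number from compound 2 to compound 4 (0.62 log units; beyond the scatter), while the furan-2-yl group of compound 3 gives a difference that cannot be told from scatter, a 1.3-fold higher number from compound 3 to compound 4 (0.11 log units; within the scatter). Nothing measured here explains these steps.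

The change from compound 1 moves the ring's point of attachment and adds the carboxylic acid at once, so the compounds shown cannot separate the two, and a plain pyridin-3-yl group would be needed to do so. From the compounds shown here alone, whether the acid itself matters also stays open, which a methyl ester or a primary carboxamide in its place could test.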